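The source may hold more compounds than are shown below. What is called first, only, known or untested is meant among the compounds shown, and "the series" means these compounds.

Of the compounds shown here, two built on a shared core have been tested in a functional assay on Ehrlich cells (Mus musculus) for cytotoxicity, tested at 25 ug/mL; a lower number here means a weaker effect, a higher number a stronger effect of the compound at the concentration tested. Compound 1 `COc1cc(N2C(N)=C(C#N)C(c3ccc(O)cc3)C3=C2CC(C)(C)CC3=O)cc(OC)c1OC` carries a 4-hydroxyphenyl group on a saturated ring carbon, and in this assay compound 1 gives 20%. Compound 2 `COc1cc(N2C(N)=C(C#N)C(c3ccc(C)cc3)C3=C2CC(C)(C)CC3=O)cc(OC)c1OC` differs from it in one place, and compound 2 gives 50%. Within the data shown here, the step between them, a number 30 percentage points higher from compound 1 to compound 2 (beyond the scatter), is the only comparison available so far, and on these two numbers compound 1 stands lowest, with compound 2 as its only neighbour and clearly higher.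

Compound 3 `COc1cc(N2C(N)=C(C#N)C(c3ccc(Cl)cc3Cl)C3=C2CC(C)(C)CC3=O)cc(OC)c1OC` has not yet been measured. It differs from compound 1 by 2,4-dichlorophenyl in place of 4-hydroxyphenyl on a saturated ring carbon. Among the measured compounds shown here, the single measured step bears on this change, since both changes take the hydroxy away from the aromatic ring and put a group without it in its place, and that step raised the number by a modest amount beyond the scatter. A step of similar direction and size is therefore expected in this assay, namely a number 30 percentage points higher from compound 1 to compound 3 (beyond the scatter). Compound 3 is expected to give 50%, with a range from 30% to 70%.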

Compound 3, a percentage reported as activity, at one concentration (the size of the read-out at that concentration, not a potency): 55%
Compound 3: middle estimate off by 5 percentage points, on the low side; low and high end bracket the measured number.
By their numbers in this assay, from the lowest: compound 1; then compounds 2 and 3 (each within the scatter of the next).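

In this assay, the result widens what was seen for the aromatic group on this saturated ring carbon: 2,4-dichlorophenyl in place of 4-hydroxyphenyl gives a number 35 percentage points higher from compound 1 to compound 3 (beyond the scatter), so a second group without the hydroxy also stands clear of compound 1. Comparing the two groups without a hydroxy, 2,4-dichlorophenyl in place of 4-methylphenyl gives a number 5 percentage points higher from compound 2 to compound 3 (within the scatter), so these two quite different substitution patterns on the ring cannot be told apart in this read-out. Nothing measured here accounts for the gap between compound 1 and the other two compounds, or for the likeness of compounds 2 and 3.

The compounds shown leave open whether the low number of compound 1 goes with the hydroxy specifically, a question that 4-methoxyphenyl, 4-aminophenyl or plain phenyl on the same carbon would help to settle. They also leave open whether one chlorine, as in 4-chlorophenyl, would fall with compounds 2 and 3, and since each number comes from a single concentration, none of this speaks to potency.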